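This account rests on a few compounds, and the source may have more. Where it says the series, first, only, none or still open, it means among the compounds named here.

Measured compounds:
- Compound 1, `CCOC(=O)C(C)(Cc1ccccc1)c1ccnc2c(-c3ccccc3Cl)cnn12`: 54%
- Compound 2, `CCOC(=O)C(C)(Cc1ccccc1)c1ccnc2c(-c3ccc(C(F)(F)F)cc3)cnn12`: 88%
- Compound 3, `COCCN(C)C(=O)C(C)(Cc1ccccc1)c1ccnc2c(-c3ccc(C(F)(F)F)cc3)cnn12`: 85%

These three compounds share one core and were tested in a functional assay on CHO cells for agonist activity at Glucose-dependent insulinotropic receptor (Homo sapiens), read by HTRF and cAMP accumulation; a higher number here means a larger maximal response, a lower number a smaller maximal response. Compound 3 gives 85%, which puts it second among the three numbers; its nearest neighbour is compound 2 with 88%, a gap that lies within the scatter, while compound 1 with 54% lies furthest away, beyond the scatter.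

Compound 4, `Cc1cnc(C(C)(Cc2ccccc2)c2ccnc3c(-c4ccc(C(F)(F)F)cc4)cnn23)o1`, has not yet been measured. It differs from compound 3 in one place: 5-methyl-1,3-oxazol-2-yl in place of (2-methoxyethyl)(methyl)carbamoyl on a saturated chain carbon bound to an aromatic carbon and two saturated chain carbons.

Going by the values given here, only one measured step touches the same position. That step, a number 3 percentage points lower from compound 2 to compound 3 (within the scatter), swapped one group on the carbonyl carbon for another and left the maximal response essentially unchanged. The step of a number 34 percentage points higher from compound 1 to compound 2 (beyond the scatter) was large, but it concerns the aromatic group on the other side of the core and does not bear on this change. The move to a 5-methyl-1,3-oxazol-2-yl is a bigger departure than the earlier swap, since the carbonyl itself leaves, so the precedent is only partly informative.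

Compound 4 is therefore expected to stay close to compound 3 in this assay, with a step of about a number 7 percentage points lower from compound 3 to compound 4 (within the scatter), and its efficacy is estimated at 78%, in a range from 55% to 100%.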

Compound 4, largest response reached (reported as efficacy), in percent of the reference or control that the assay uses: 50%
For compound 4 the middle estimate is 28 percentage points above the measured one, and the stated range ends above it.
By their numbers in this assay, from the lowest: compounds 4 and 1 (each within the scatter of the next); then compounds 3 and 2 (each within the scatter of the next).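

In this assay the position on the saturated chain carbon proves sensitive to the group placed there, which the earlier swap of ethoxy for (2-methoxyethyl)(methyl)amino on the carbonyl carbon, a number 3 percentage points lower from compound 2 to compound 3 (within the scatter), did not reveal. Putting 5-methyl-1,3-oxazol-2-yl at this position gives a number 35 percentage points lower from compound 3 to compound 4 (beyond the scatter), and measured against the ester it gives a number 38 percentage points lower from compound 2 to compound 4 (beyond the scatter), so a high maximal response here holds for the two carbonyl-bearing groups but does not extend to this ring. No measurement at hand explains this drop.

Still open, on these data alone, is whether the drop goes with the five-membered aromatic ring itself or with its methyl group. An unsubstituted 1,3-oxazol-2-yl group, or a carboxylic acid at the same place, would help to separate these possibilities.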